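The compounds below may be only part of what the source reports. "The series", "measured", "known", "first", "only" and "open" are said of these compounds alone.

Compound 1: `COc1ccccc1CC1(OC)CCN(c2ccc(C(=O)NS(=O)(=O)c3ccc(N[C@H](CCN(C)C)CSc4ccccc4)c([N+](=O)[O-])c3)cc2)CC1`, 1.6 nM
Compound 2: `CN(C)CC[C@H](CSc1ccccc1)Nc1ccc(S(=O)(=O)NC(=O)c2ccc(N3CCC(=Cc4ccc(F)cc4)CC3)cc2)cc1[N+](=O)[O-]`, 3.4 nM
Compound 3: `CN(C)CC[C@H](CSc1ccccc1)Nc1ccc(S(=O)(=O)NC(=O)c2ccc(N3CCN(C(=O)Nc4ccccc4)CC3)cc2)cc1[N+](=O)[O-]`, 300 nM

All three were tested in an assay on isolated protein for displacement of a labelled ligand from Apoptosis regulator Bcl-2 (Homo sapiens), read by fluorescence polarization; on this read-out lower numbers stand for stronger inhibition and higher numbers for weaker inhibition. Compound 3 stands at the top of the numbers, with 300 nM. Compound 2 gives 3.4 nM, and compound 1 gives 1.6 nM. Both gaps to compound 3 lie well beyond the usual scatter, so compound 3 is the weakest binder of the three measured.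

Compound 4, `CN(C)CC[C@H](CSc1ccccc1)Nc1ccc(S(=O)(=O)NC(=O)c2ccc(N3CCN(Cc4ccccc4C(F)(F)F)CC3)cc2)cc1[N+](=O)[O-]`, has not yet been measured. It differs from compound 3 in a single place: 2-(trifluoromethyl)benzyl in place of phenylcarbamoyl on an amine nitrogen in a ring. For the measured compounds named here, no measured pair shows this exact change, so the size of the step cannot be read off directly. What the numbers do show is that the two compounds without a phenylcarbamoyl group on the ring attached to the shared core sit far lower: compound 1 gives 1.6 nM and compound 2 gives 3.4 nM. On that basis a downward step from compound 3 to compound 4 is expected, a 12-fold lower number from compound 3 to compound 4 (1.08 log units; beyond the scatter), with the caution that this rests on a single comparison. Compound 4 is estimated at 25 nM, within a range from 5 nM to 120 nM.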

Compound 4, inhibition constant: < 1 nM
Compound 4: a limit, no number; the forecaster's own chance of this, stated with the estimate: 2%; middle value at least 25-fold (1.39 log units) from the limit.
By their numbers in this assay, from the lowest: compound 1; then compound 2; then compound 3. At a limit, below all of these: compound 4.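

Swapping phenylcarbamoyl for 2-(trifluoromethyl)benzyl on an amine nitrogen in a ring gives an at least 300-fold lower number from compound 3 to compound 4 (2.47 log units; beyond the scatter), the first view of this position changed in one place alone. The group on this nitrogen can therefore decide between weak and strong binding in this assay, and the six-membered ring with 2 nitrogen does not by itself hold the number up, as compound 4 keeps that ring. Compound 4 gives < 1 nM, which is a limit of the assay and not a number, so the step has a floor but no known full size: the limit of < 1 nM in this assay, at which 1 of the 4 values shown sits.

For the compounds shown here, the single swap changes several things at once, including the loss of a hydrogen-bond donor and the arrival of three fluorines. A plain benzyl group or an acetyl group on the same nitrogen would help tell which of these matters.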